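The source may hold more compounds than are shown below. What is called first, only, known or untested is meant among the compounds shown, and "the series" means these compounds.

In a functional assay on NCI-H460 cells (Homo sapiens) for inhibition, read by sulforhodamine B assay, with a stated time of 48 h (a higher number here means a weaker inhibitor of growth, a lower number a stronger inhibitor of growth), compound 2 `CC1=CC[C@H](C(C)(C)NC(=S)N/N=C/c2ccc[nH]2)CC1` gives 18000 nM, the highest of the two numbers measured, while compound 1 `CC1=CC[C@H](C(C)(C)NC(=S)N/N=C/c2ccc(Cl)cc2)CC1` gives 7800 nM. Going by the values given here, the only measured step, a 2.3-fold higher number from compound 1 to compound 2 (0.36 log units; beyond the scatter), is modest and points to a weaker effect. Compound 3 `CC1=CC[C@H](C(C)(C)NC(=S)N/N=C/c2cccs2)CC1` differs from compound 2 by thiophen-2-yl in place of 1H-pyrrol-2-yl on a carbon with a double bond to nitrogen. Among the compounds with values here, no measured step involves this change, so the expectation rests loosely on compound 1 and compound 2. Compound 3 is expected to give 12000 nM, with a likely range from 5000 nM to 30000 nM. The step expected from compound 2 to compound 3 is a 1.5-fold lower number from compound 2 to compound 3 (0.18 log units; within the scatter), within the usual scatter.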

Compound 3, concentration for 50% growth inhibition: 10800 nM
Estimate against measurement, compound 3: 1.1-fold (0.05 log units) above, within the range that was stated.
By their numbers in this assay, from the lowest: compounds 1, 3 and 2 (each within the scatter of the next, the first and the last beyond it).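

At this position, on a carbon with a double bond to nitrogen, thiophen-2-yl and 1H-pyrrol-2-yl cannot be told apart in this assay (a 1.7-fold lower number from compound 2 to compound 3 (0.22 log units; within the scatter)), and neither can thiophen-2-yl and 4-chlorophenyl (a 1.4-fold higher number from compound 1 to compound 3 (0.14 log units; within the scatter)). Trading the hydrogen-bond donor of 1H-pyrrol-2-yl for the sulfur of thiophen-2-yl therefore stays within the scatter, and only compound 1 and compound 2 lie beyond it from each other. No measurement here offers an explanation for this.

On these data alone, how an open chain such as butyl, or an amine such as dimethylamino, would read at this position stays open.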